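The source may hold more compounds than are shown below. What is called first, only, known or untested is meant among the compounds shown, and "the series" means these compounds.

Values in an assay on HeLa cells for displacement of a labelled ligand from 5-hydroxytryptamine receptor 6 (Homo sapiens) (on this read-out higher numbers stand for weaker inhibition and lower numbers for stronger inhibition), for the measured compounds:

- compound 1, `COc1ccc(S(=O)(=O)c2n[nH]c3cc(N4CCNCC4)ccc23)cc1`, gives 124 nM
- compound 2, `Cc1ccc(S(=O)(=O)c2n[nH]c3cccc(N4CCNCC4)c23)cc1`, gives 134 nM
- compound 3, `Cc1ccc(S(=O)(=O)c2n[nH]c3cc(N4CCNCC4)ccc23)cc1`, gives 27 nM

Compound 4, `COc1ccc(S(=O)(=O)c2n[nH]c3cccc(N4CCNCC4)c23)cc1`, is not yet measured in this assay. Compound 4 differs from compound 2 by methoxy in place of methyl on an aromatic carbon. The same change has been made once among the measured compounds, from compound 3 to compound 1, (methoxy in place of methyl on an aromatic carbon), and there it gave a 4.6-fold higher number from compound 3 to compound 1 (0.66 log units; beyond the scatter). The two place descriptions are the same word for word, so this is the same change on a different core. Compound 2 and compound 3 have the same atoms joined differently; the difference between the two cores is not broken down here. Compound 2 and compound 1 give numbers within the scatter of each other, while compound 3 gives a lower number than compound 2, beyond the scatter.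

The step from compound 2 to compound 4 is expected to be a 3.4-fold higher number from compound 2 to compound 4 (0.53 log units; beyond the scatter), weaker in pull than the measured precedent, because a 4.6-fold higher number from compound 3 to compound 1 (0.66 log units; beyond the scatter) is a single case on a core whose difference from the core of compound 2 is not resolved here, and a second core need not repeat it fully. With compound 2 as the starting point, compound 4 is estimated at 450 nM in this assay, with a range from 150 nM to 1500 nM.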

Compound 4, inhibition constant: 88 nM
The estimate for compound 4 lay 5.1-fold (0.71 log units) above the measured number, and the stated range ends above it.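

On the core of compound 2, methoxy in place of methyl on an aromatic carbon gives a 1.5-fold lower number from compound 2 to compound 4 (0.18 log units; within the scatter) in this assay and so leaves the number within the scatter. This shows that the change does not carry a fixed size from one core to the other in this series, but with a single pair on each core it does not show which difference between the two cores sets the steps apart, and it gives no rule for predicting the step on a further core. The two steps differ: the same change on two cores in this assay, a 4.6-fold higher number (0.66 log units; beyond the scatter) from compound 3 to compound 1 and a 1.5-fold lower number (0.18 log units; within the scatter) from compound 2 to compound 4, 7.0-fold (0.84 log units) apart, beyond the scatter of two such steps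

The compounds shown leave open whether another group in place of the methyl of 4-methylphenyl, such as chlorine, trifluoromethyl, an amine or a carboxylic acid, would also give steps that differ between these two cores. They also leave open whether a pair on a further core would follow the step on the core of compound 1, the step on the core of compound 2, or neither of them.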